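The source may hold more compounds than are shown below. What is called first, only, known or untested is meant among the compounds shown, and "the series" means these compounds.

Series notes, sulfonyl substituent on the acyl sulfonamide.

Three compounds share the core and differ only at the sulfonyl sulfur. In a physicochemical assay for permeability, using PAMPA, at pH 7.4 (on this read-out higher numbers stand for higher permeability and lower numbers for lower permeability), compound 1 `Cc1ccccc1S(=O)(=O)NC(=O)c1ccc(Nc2nc(NC3(c4ccc(Cl)cc4)CC3)nc(OCC(F)(F)F)n2)cc1` gives 265 nm/s, compound 2 `CNC(=O)NCCS(=O)(=O)NC(=O)c1ccc(Nc2nc(NC3(c4ccc(Cl)cc4)CC3)nc(OCC(F)(F)F)n2)cc1` gives 40 nm/s, and compound 3 `CS(=O)(=O)NC(=O)c1ccc(Nc2nc(NC3(c4ccc(Cl)cc4)CC3)nc(OCC(F)(F)F)n2)cc1` gives 11 nm/s. Compound 3 stands lowest of the three: a 24-fold lower number from compound 1 to compound 3 (1.38 log units; beyond the scatter), and a 3.6-fold lower number from compound 2 to compound 3 (0.56 log units; beyond the scatter). The remaining step is a 6.6-fold lower number from compound 1 to compound 2 (0.82 log units; beyond the scatter).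

Compound 4 `CC(C)(C)CNCCS(=O)(=O)NC(=O)c1ccc(Nc2nc(NC3(c4ccc(Cl)cc4)CC3)nc(OCC(F)(F)F)n2)cc1` is not yet measured in this assay. Its change from compound 3 is (neopentylamino)methyl in place of hydrogen on a saturated chain carbon bound to a sulfonyl sulfur. The step that bears most directly on it runs the other way between compound 2 and compound 3, where a 3.6-fold lower number from compound 2 to compound 3 (0.56 log units; beyond the scatter); compound 4 likewise carries a chain on the carbon bound to the sulfonyl sulfur, though with a different end group, so a rise of comparable size beyond the scatter is expected. The larger step of a 24-fold lower number from compound 1 to compound 3 (1.38 log units; beyond the scatter) involved an aryl group rather than a chain and sets only an upper bound on what such a change has done in this series.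

Compound 4 is therefore expected to read above compound 3, with a 4.1-fold higher number from compound 3 to compound 4 (0.61 log units; beyond the scatter), giving an estimate of 45 nm/s within a range of 15 nm/s to 140 nm/s.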

Compound 4, apparent permeability: 651 nm/s
For compound 4 the middle estimate is 14-fold (1.16 log units) below the measured one, and the stated range ends below it.
By their numbers in this assay, from the lowest: compound 3; then compound 2; then compound 1; then compound 4.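

Series notes, continued. In this assay a chain on the carbon bound to the sulfonyl sulfur can move the number far more than the earlier chain suggested: (neopentylamino)methyl in place of hydrogen on that carbon gives a 59-fold higher number from compound 3 to compound 4 (1.77 log units; beyond the scatter) and so exceeds every step seen among the first three compounds. The end of the chain matters at least as much as its presence, as neopentyl in place of methylcarbamoyl on an amine nitrogen gives a 16-fold higher number from compound 2 to compound 4 (1.21 log units; beyond the scatter) with the rest of the molecule unchanged. The aryl group also no longer marks the top of the set: exchanging it for the chain gives a 2.5-fold higher number from compound 1 to compound 4 (0.39 log units; beyond the scatter) and leaves compound 4 highest of the four, with a group that has no ring.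

The compounds shown do not separate the neopentyl group from the amine nitrogen, and an ethyl or cyclohexyl group on that nitrogen, an ether oxygen in its place, or a longer chain on the sulfonyl sulfur would bear on this. No measurement at hand accounts for the size of these steps.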